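Sulfonamide nitrogen substituent in the butylpyridinone tetrazole series

The source may report more compounds than this note shows. Statements on the series, on what has been measured and on what is new or still open speak of the compounds shown alone.

Measured compounds:
- compound 1, `CCCCNC(=O)NCc1ccc(CCCC)n(Cc2ccc(-c3ccccc3-c3nn[nH]n3)cc2)c1=O`, 10 nM
- compound 2, `CCCCc1ccc(CNS(=O)(=O)c2ccccc2)c(=O)n1Cc1ccc(-c2ccccc2-c2nn[nH]n2)cc1`, 7 nM
- compound 3, `CCCCc1ccc(CN(Cc2ccccc2)S(C)(=O)=O)c(=O)n1Cc1ccc(-c2ccccc2-c2nn[nH]n2)cc1`, 2 nM

All three were tested in a functional assay (aorta) for antagonist activity, with Oryctolagus cuniculus as the target; on this read-out lower numbers stand for stronger inhibition and higher numbers for weaker inhibition. Compound 3 stands lowest of the three numbers; the nearest is compound 2, with a 3.5-fold lower number from compound 2 to compound 3 (0.54 log units; beyond the scatter), and the furthest is compound 1, with a 5.0-fold lower number from compound 1 to compound 3 (0.70 log units; beyond the scatter). Between compound 1 and compound 2 the change is a 1.4-fold lower number from compound 1 to compound 2 (0.15 log units; within the scatter).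

Compound 4, `CCCCc1ccc(CN(C(C)C)S(C)(=O)=O)c(=O)n1Cc1ccc(-c2ccccc2-c2nn[nH]n2)cc1`, has not been measured in this assay. Relative to compound 3 the change is isopropyl in place of benzyl on a sulfonamide nitrogen. Within the data shown here, no measured step alters the group on the sulfonamide nitrogen alone; the two steps that bear on it, a 5.0-fold lower number from compound 1 to compound 3 (0.70 log units; beyond the scatter) and a 3.5-fold lower number from compound 2 to compound 3 (0.54 log units; beyond the scatter), both introduce the benzyl(methylsulfonyl)amino group as a whole and do not separate the benzyl part from the methylsulfonyl part. The expectation for compound 4 is therefore a modest loss, a 2.0-fold higher number from compound 3 to compound 4 (0.30 log units; within the scatter), with a wide range. Compound 4 is estimated at 4 nM, between 1.5 nM and 12 nM.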

Compound 4, half-maximal inhibitory concentration: 0.9 nM
For compound 4 the middle estimate is 4.4-fold (0.65 log units) above the measured one; the whole stated range lies above it.
By their numbers in this assay, from the lowest: compound 4; then compound 3; then compounds 2 and 1 (each within the scatter of the next).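

In this assay, the group on the sulfonamide nitrogen now has a step of its own: isopropyl in place of benzyl gives (a 2.2-fold lower number from compound 3 to compound 4 (0.35 log units; beyond the scatter)), so the benzyl group and its six-membered aromatic ring are not required for a low number at this position. Among these compounds, on the saturated chain carbon, the isopropyl(methylsulfonyl)amino group also stands clear of the (phenylsulfonyl)amino group (a 7.8-fold lower number from compound 2 to compound 4 (0.89 log units; beyond the scatter)) and the (butylcarbamoyl)amino group (an 11-fold lower number from compound 1 to compound 4 (1.05 log units; beyond the scatter)), and the latter is the only step of this set printed as large. Nothing at hand accounts for the lower number with isopropyl.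

The compounds shown leave open how a methyl, a cyclopropyl, a tert-butyl or a longer chain such as butyl would compare with isopropyl on this nitrogen. They also leave open whether phenylsulfonyl could replace methylsulfonyl while isopropyl stays in place.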